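This account rests on a few compounds, and the source may have more. Where it says the series, first, only, none or still open, it means among the compounds named here.

Working notes on the series. In a functional assay on K562 cells (Homo sapiens) for cytotoxicity (on this read-out lower numbers stand for stronger inhibition and higher numbers for weaker inhibition), compound 1 `CCC(CO)Nc1nc(NCc2ccccc2)c2nc(N)n(C(C)C)c2n1` gives 80000 nM, compound 2 `CCC(CO)Nc1nc(NCc2ccccc2)c2nc([N+](=O)[O-])n(C(C)C)c2n1` gives 117000 nM and compound 3 `CCCOc1nc2c(NCc3ccccc3)nc(NC(CC)CO)nc2n1C(C)C` gives 20000 nM. Compound 3 holds the lowest of the three numbers, and the two steps leading to it lie beyond the scatter: a 4.0-fold lower number from compound 1 to compound 3 (0.60 log units; beyond the scatter) and a 5.9-fold lower number from compound 2 to compound 3 (0.77 log units; beyond the scatter). The remaining step, a 1.5-fold higher number from compound 1 to compound 2 (0.17 log units; within the scatter), lies within the scatter.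

Compound 4 `CCC(CO)Nc1nc(NCc2ccccc2)c2nc(NCCCO)n(C(C)C)c2n1` follows from compound 3 with (3-hydroxypropyl)amino in place of propoxy on an aromatic carbon. For the measured compounds named here, no measured compound carries this group, so the nearest guide is compound 1, with amino at the same place, and its step of a 4.0-fold lower number from compound 1 to compound 3 (0.60 log units; beyond the scatter) read backwards. On that basis, a modest move to a higher number is expected, with most of the gap to compound 1 possibly regained. The expected change is a 2.5-fold higher number from compound 3 to compound 4 (0.40 log units; beyond the scatter). Compound 4 is estimated at 50000 nM, with an expected range from 20000 nM to 120000 nM.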

Compound 4, half-maximal inhibitory concentration: 30000 nM
Estimate against measurement, compound 4: 1.7-fold (0.22 log units) above; the measured number falls inside the stated range.
By their numbers in this assay, from the lowest: compounds 3 and 4 (each within the scatter of the next); then compounds 1 and 2 (each within the scatter of the next).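

In this assay the position on the aromatic carbon between two ring nitrogen atoms accepts (3-hydroxypropyl)amino in place of propoxy with no change beyond the scatter (a 1.5-fold higher number from compound 3 to compound 4 (0.18 log units; within the scatter)), even though the entering group counts 2 hydrogen-bond donors and the leaving group 0. The 3-hydroxypropyl chain on the nitrogen also separates this compound from the plain amino group (a 2.7-fold lower number from compound 1 to compound 4 (0.43 log units; beyond the scatter)) and from nitro (a 3.9-fold lower number from compound 2 to compound 4 (0.59 log units; beyond the scatter)), so among these compounds both chain-bearing groups stand apart from amino and nitro, with none going against this. No measurement here accounts for these differences.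

As far as these compounds go, whether the hydroxyl of the chain plays any part stays open, as a plain propylamino group would show. From the compounds shown here alone, the effect of chain length also stays open, for example with (5-hydroxypentyl)amino or a chain ending in a carboxylic acid.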